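Aryl Cap Returns on the Azole Nitrogen

The source may hold more compounds than are shown below. What is called first, only, known or untested is meant among the compounds shown, and "the series" means these compounds.

Compound 3 `CNC(=O)[C@@]12C[C@@H]1[C@@H](n1cnc3c(NCc4cccc(Cl)c4)nc(C#CCCCCc4cn(CCNC(C)=O)nn4)nc31)[C@H](O)[C@@H]2O` stands lowest of the three measured compounds in an assay on CHO cells for displacement of a labelled ligand from adenosine receptor A3 (Homo sapiens), read by scintillation counting (on this read-out higher numbers stand for weaker inhibition and lower numbers for stronger inhibition), where compound 3 gives 22.3 nM. Compound 2 `CNC(=O)[C@@]12C[C@@H]1[C@@H](n1cnc3c(NCc4cccc(Cl)c4)nc(C#CCCCCc4cn(CCCCN)nn4)nc31)[C@H](O)[C@@H]2O` gives 47 nM and compound 1 `CNC(=O)[C@@]12C[C@@H]1[C@@H](n1cnc3c(NCc4cccc(Cl)c4)nc(C#CCCCCc4cn(-c5ccc(N)cc5)nn4)nc31)[C@H](O)[C@@H]2O` gives 87.1 nM, with steps of a 2.1-fold lower number from compound 2 to compound 3 (0.32 log units; beyond the scatter) and a 3.9-fold lower number from compound 1 to compound 3 (0.59 log units; beyond the scatter). Compound 4 `CNC(=O)[C@@]12C[C@@H]1[C@@H](n1cnc3c(NCc4cccc(Cl)c4)nc(C#CCCCCc4cn(-c5cccc([N+](=O)[O-])c5)nn4)nc31)[C@H](O)[C@@H]2O` differs from compound 3 by 3-nitrophenyl in place of 2-acetamidoethyl on an aromatic nitrogen. Going by the values given here, the step bearing most closely on this change is the one involving compound 1, which also carries a six-membered aromatic ring on that nitrogen; reversing that modest step would move the number back upward. The expectation for compound 4 is therefore a higher number than compound 3 in this assay, with a 2.7-fold higher number from compound 3 to compound 4 (0.43 log units; beyond the scatter). Compound 4 is estimated at 60 nM, within a range from 20 nM to 180 nM.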

Compound 4, inhibition constant: 10.6 nM
For compound 4 the middle estimate is 5.7-fold (0.75 log units) above the measured one; measured number below the stated range.
By their numbers in this assay, from the lowest: compound 4; then compound 3; then compounds 2 and 1 (each within the scatter of the next).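

On this aromatic nitrogen, an aromatic ring does not by itself raise the number in this assay: 3-nitrophenyl gives a 2.1-fold lower number from compound 3 to compound 4 (0.32 log units; beyond the scatter), and replacing the 4-aminobutyl chain gives a 4.4-fold lower number from compound 2 to compound 4 (0.65 log units; beyond the scatter). The two aryl groups also differ sharply from each other, with an 8.2-fold lower number from compound 1 to compound 4 (0.91 log units; beyond the scatter), the widest step shown. Nothing available gives a reason for these steps.

The two rings differ in both substituent and its place, and the compounds shown leave open which one accounts for that gap. A plain phenyl or a ring bearing a nitrile would bear on this question.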